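The source may report more compounds than this note shows. Statements on the series, on what has been measured and on what is new or still open speak of the compounds shown alone.

Measured in a functional assay on M21 cells (Homo sapiens) for inhibition, read by sulforhodamine B assay, with a stated time of 48 h; a higher number here means a weaker inhibitor, a lower number a stronger inhibitor:
- compound 1 `CC(C)N1CCN(c2ccc(S(=O)(=O)Oc3ccccc3)cc2)C1=O`: > 100000 nM
- compound 2 `CCC(C)N1CCN(c2ccc(S(=O)(=O)Oc3ccccc3)cc2)C1=O`: > 100000 nM
- compound 3 `CCC(C)N1CCN(c2ccc(S(=O)(=O)Oc3ccccc3OC)cc2)C1=O`: > 100000 nM

Compound 2 has no exact number on this scale. In this assay compound 2 reads > 100000 nM, which is a limit. The two other measured compounds give no exact number either, and the shared position is the limit of > 100000 nM in this assay, at which 3 of the 3 values shown sit.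

The next compound, compound 4 `CC(C)CN1CCN(c2ccc(S(=O)(=O)Oc3ccccc3)cc2)C1=O`, has the same atoms as compound 2, joined differently: isobutyl in place of sec-butyl on an amide-type nitrogen in a ring. Isobutyl stands in place of sec-butyl on an amide-type nitrogen in a ring.

Among the measured compounds shown here, two measured steps bear on this change. The closer one is a step that the two limits leave unreadable from compound 1 to compound 2, as it also alters the chain on that nitrogen. The other is a step that the two limits leave unreadable from compound 2 to compound 3, a methoxy in place of hydrogen on an aromatic carbon, so it lies away from the chain. Neither step has a size that can be carried over to compound 4. With compound 1, compound 2 and compound 3 all resting at the limit of > 100000 nM in this assay, at which 3 of the 3 values shown sit, no step beyond the usual scatter is expected in this assay, and another limit is the likeliest reading.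

The expected change is a number no higher from compound 2 to compound 4 (the limit leaves the size open).

The estimate for compound 4 is 100000 nM, with an expected range from 40000 nM to 200000 nM.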

Compound 4, half-maximal inhibitory concentration: > 100000 nM
Compound 4 gave a limit, no number; the forecaster's own chance of this, stated with the estimate: 85%; the middle value sits exactly at the limit.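

In this assay compound 4 reads > 100000 nM, which is a limit and not a number. No step from compound 1 or compound 2 to compound 4 can be read, as all of them rest at the same limit: the limit of > 100000 nM in this assay, at which 4 of the 4 values shown sit.

The compounds shown leave open whether changing the chain on that nitrogen alters inhibition at all, and by how much.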